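The compounds below may be only part of what the source reports. "The series", "measured", "known", "first", "only" and "open" are said of these compounds alone.

Working notes on the series in a functional assay on C6 cells (Rattus norvegicus) for cytotoxicity, read by MTT assay, with a stated time of 24 h; a higher number here means a weaker inhibitor, a lower number a stronger inhibitor.

Compound 1 `O=C(CSc1ncccn1)N/N=c1/scc(-c2ccc(Br)cc2)n1-c1ccccc1` gives only a limit in this assay, > 200 ug/mL, and not a number. Compound 2 `O=C(CSc1nnnn1-c1ccccc1)N/N=c1/scc(-c2ccccc2)n1-c1ccccc1` gives 8.3 ug/mL in this assay. Compound 3 `O=C(CSc1nnnn1-c1ccccc1)N/N=c1/scc(-c2ccc([N+](=O)[O-])cc2)n1-c1ccccc1` has no number in this assay: its value is "not determined" (no result reported), so compound 3 stands nowhere on the numbers shown, and no step from it to another compound can be sized. Among the measured compounds shown here, the only numerical anchor is compound 2, while compound 1 sits at a limit, as noted in the limit of > 200 ug/mL in this assay, at which 1 of the 3 values shown sits.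

Compound 4 `O=C(CSc1nnnn1-c1ccccc1)N/N=c1/scc(-c2ccc(Br)cc2)n1-c1ccccc1` differs from compound 3 by bromo in place of nitro on an aromatic carbon. For the measured compounds named here, no step between measured compounds isolates this change, so its size and direction in this assay are open; with compound 3 itself unmeasured there is no starting number to step from.

Compound 4 shares its core with compound 2 and its bromophenyl with compound 1, and its value in this assay is expected to fall between those two, estimated at 30 ug/mL within 5 ug/mL to 200 ug/mL.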

Compound 4, half-maximal inhibitory concentration: 21 ug/mL
Beside the measured number, compound 4's estimate is 1.4-fold (0.15 log units) above it; measured number inside the range.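

In this assay, the aromatic carbon that carries the bromo gets its first reading: bromo in place of hydrogen gives a 2.5-fold higher number from compound 2 to compound 4 (0.40 log units; beyond the scatter), so a substituent at this place shifts the number, and in this pair it moves towards a weaker inhibitor. Among the compounds shown here, with the 4-bromophenyl held fixed, 1-phenyl-1H-tetrazol-5-yl in place of pyrimidin-2-yl on the sulfur gives an at least 9.5-fold lower number from compound 1 to compound 4 (0.97 log units; beyond the scatter), which shows for the first time that the group on the sulfur also matters. That step starts from a limit and not a number, so its full size stays unknown: the limit of > 200 ug/mL in this assay, at which 1 of the 4 values shown sits.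

The change from 4-nitrophenyl to 4-bromophenyl cannot be read as a step. From the compounds shown here alone, how an amine or a carboxylic acid at this aromatic carbon would compare with hydrogen and bromo remains open.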